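The source may hold more compounds than are shown below. What is called first, only, known or untested is meant among the compounds shown, and "the series" means these compounds.

Compound 3 `O=C1O[C@@H](CNC(=O)C(F)(F)F)CN1c1ccc(-n2cc(-c3ccccn3)cn2)c(F)c1` stands highest among the three compounds measured in a physicochemical assay for solubility, read by HPLC, with a stated time of 24 h; a higher number here means a more soluble compound, a lower number a less soluble compound: compound 3 gives 114000 nM, whereas compound 1 `COC[C@H]1CN(c2ccc(-n3cc(-c4ccccn4)cn3)c(F)c2)C(=O)O1` gives 36200 nM and compound 2 `O=C1O[C@@H](CSc2cccs2)CN1c1ccc(-n2cc(-c3ccccn3)cn2)c(F)c1` gives 8500 nM. Compound 4 `NC(=O)[C@H]1CN(c2ccc(-n3cc(-c4ccccn4)cn3)c(F)c2)C(=O)O1` differs from compound 3 by carbamoyl in place of (((trifluoromethyl)carbonyl)amino)methyl on a saturated ring carbon. Among the compounds with values here, none of the measured steps makes this same change; the closest guides are the exchanges at the saturated chain carbon, where a 3.1-fold higher number from compound 1 to compound 3 (0.50 log units; beyond the scatter) and a 13-fold higher number from compound 2 to compound 3 (1.13 log units; beyond the scatter), while a 4.3-fold lower number from compound 1 to compound 2 (0.63 log units; beyond the scatter). Since these steps are modest to large in this assay, a modest shift is expected for compound 4, in either direction, most likely a small decrease of a 1.9-fold lower number from compound 3 to compound 4 (0.28 log units; within the scatter). Compound 4 is therefore estimated at 60000 nM, with a range from 15000 nM to 200000 nM.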

Compound 4, solubility: 27200 nM
Estimate against measurement, compound 4: 2.2-fold (0.34 log units) above; the measured number falls inside the stated range.
By their numbers in this assay, from the lowest: compound 2; then compounds 4 and 1 (each within the scatter of the next); then compound 3.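

In this assay, carbamoyl on the saturated ring carbon gives a 4.2-fold lower number from compound 3 to compound 4 (0.62 log units; beyond the scatter), although the two groups have the same counts of hydrogen-bond donors and acceptors, so those counts alone do not fix the number at this position. It also gives a 3.2-fold higher number from compound 2 to compound 4 (0.51 log units; beyond the scatter), while a 1.3-fold lower number from compound 1 to compound 4 (0.12 log units; within the scatter) shows that carbamoyl and methoxymethyl cannot be told apart here. Nothing measured here explains these steps. On these data alone, how a carboxylic acid or an amine on this ring carbon would read remains open. So does whether a longer chain ending in carbamoyl would read differently from carbamoyl itself.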